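The compounds below may be only part of what the source reports. "The series", "measured", "known", "first", "only" and "open" are said of these compounds alone.

Compound 3 `O=C(O)CCn1c(=O)oc2cc(OCC3CCC3)c(Cl)cc21` sits at the high end of the three numbers in hand. In an assay for inhibition of kynurenine 3-monooxygenase (Homo sapiens), read by mass spectrometry, with a stated time of 1 h (a lower number here means a stronger inhibitor, a higher number a weaker inhibitor), compound 3 gives 25.1 nM. For the measured compounds named here, its nearest neighbour is compound 1 `CC(C)Cc1cc2oc(=O)n(CCC(=O)O)c2cc1Cl`, which in this assay gives 12.6 nM; the only direct step measured here, a 2.0-fold higher number from compound 1 to compound 3 (0.30 log units; within the scatter), is small and carries no clear lesson. Compound 2 `Cc1ccnc([C@@H](C)Oc2cc3oc(=O)n(CCC(=O)O)c3cc2Cl)c1` stands furthest away and in this assay gives 3.98 nM, a number beyond the scatter from compound 3.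

Compound 4 `C[C@@H](Oc1cc2oc(=O)n(CCC(=O)O)c2cc1Cl)c1ncco1` is reached from compound 3 by one change: a group of 7 heavy atoms (5 carbon, 1 nitrogen, 1 oxygen; one five-membered aromatic ring with 2 hetero atoms) in place of a group of 5 heavy atoms (5 carbon; one four-membered non-aromatic ring of carbon only), on an oxygen on an aromatic ring. Going by the values given here, no measured step matches this exact exchange, so the expectation rests on the spread of the three values. Compound 2 shows that a member of this family with a different side group can reach a value well under that of compound 3, and compound 4 is expected to move in the same direction. The step expected for compound 4 is a 3.1-fold lower number from compound 3 to compound 4 (0.50 log units; beyond the scatter), and its size is uncertain. For compound 4 in this assay the estimate is 8 nM, within a range from 2.5 nM to 25 nM.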

Compound 4, half-maximal inhibitory concentration: 3.16 nM
Compound 4: the middle estimate sits 2.5-fold (0.40 log units) above what was measured; the measured number falls inside the stated range.
By their numbers in this assay, from the lowest: compounds 4 and 2 (each within the scatter of the next); then compounds 1 and 3 (each within the scatter of the next).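

The step of a 7.9-fold lower number from compound 3 to compound 4 (0.90 log units; beyond the scatter) in this assay shows that, on this oxygen on an aromatic ring, cyclobutylmethyl can be exchanged for a group with a five-membered aromatic ring with a clear gain, and a 4.0-fold lower number from compound 1 to compound 4 (0.60 log units; beyond the scatter) places that group well ahead of the isobutyl-bearing compound too. The low number is therefore not unique to compound 2. With a 1.3-fold lower number from compound 2 to compound 4 (0.10 log units; within the scatter), 1,3-oxazol-2-yl and 4-methylpyridin-2-yl cannot be told apart in this measurement, so two different aromatic rings serve equally well here.

Nothing available explains why these rings give lower numbers. The compounds shown leave open whether the ring or the defined stereocentre entering with it matters more, and how a phenyl ring or an amine on that chain carbon would compare.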